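The source may hold more compounds than are shown below. What is called first, only, known or untested is meant among the compounds shown, and "the series" means these compounds.

Measured in a functional assay on A549 cells (Homo sapiens) for inhibition, read by MTT assay, with a stated time of 48 h; on this read-out lower numbers stand for stronger inhibition and higher numbers for weaker inhibition:
compound 1 `Oc1cccc(C(c2c[nH]c3ccc(Br)cc23)c2c[nH]c3ccc(Br)cc23)c1` gives 8000 nM
compound 2 `COc1cccc(C(c2c[nH]c3ccc(Br)cc23)c2c[nH]c3ccc(Br)cc23)c1OC` gives 100000 nM
compound 3 `COc1ccc(C(c2c[nH]c3ccc(Br)cc23)c2c[nH]c3ccc(Br)cc23)cc1OC` gives 12000 nM

Compound 1 sits at the low end of these three numbers, though not alone. One step stays within the scatter (a 1.5-fold higher number from compound 1 to compound 3 (0.18 log units; within the scatter)) and the other is large (a 13-fold higher number from compound 1 to compound 2 (1.10 log units; beyond the scatter)).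

Compound 4 `Brc1ccc2[nH]cc(C(c3ccc4ccccc4c3)c3c[nH]c4ccc(Br)cc34)c2c1` has not been measured yet. It carries naphthalen-2-yl in place of 3-hydroxyphenyl on a saturated chain carbon bound to two aromatic carbons.

Among the compounds with values here, all three measured steps change the group at this same place, so they are the only guide available. Replacing 3-hydroxyphenyl has therefore cost either almost nothing or a great deal. Exchanging 2,3-dimethoxyphenyl for 3,4-dimethoxyphenyl also gave a modest step (an 8.3-fold lower number from compound 2 to compound 3 (0.92 log units; beyond the scatter)), which shows that the outcome in this assay can turn on the group chosen. Within the data shown here, no measured compound carries naphthalen-2-yl, so neither precedent transfers directly.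

The expected result is no step beyond the scatter, with a slight lean towards a higher number (a 1.8-fold higher number from compound 1 to compound 4 (0.24 log units; within the scatter)). The estimate for compound 4 is 14000 nM, within an expected range of 5000 nM to 60000 nM, and the wide upper end allows for a large step like the one seen with 2,3-dimethoxyphenyl.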

Compound 4, half-maximal inhibitory concentration: 8500 nM
Compound 4: middle estimate off by 1.6-fold (0.22 log units), on the high side; measured number inside the range.
By their numbers in this assay, from the lowest: compounds 1, 4 and 3 (each within the scatter of the next); then compound 2.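

In this assay the change to naphthalen-2-yl gives no real shift (a 1.1-fold higher number from compound 1 to compound 4 (0.03 log units; within the scatter)), even though this group has more heavy atoms than 3-hydroxyphenyl and no hydrogen-bond donor or acceptor, so among these compounds neither feature of 3-hydroxyphenyl is needed to stay in this range. The comparison with the other dimethoxy compound points the same way (a 1.4-fold lower number from compound 3 to compound 4 (0.15 log units; within the scatter)), so compounds 1, 3 and 4 now form one group with no order among them, and groups of quite different make-up fit it at this place on a saturated chain carbon bound to two aromatic carbons. Only 2,3-dimethoxyphenyl stands apart (a 12-fold lower number from compound 2 to compound 4 (1.07 log units; beyond the scatter)), which makes compound 2 the single exception rather than one end of a gradual trend.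

No supporting measurement explains why compound 2 alone separates from the others. As far as these compounds go, it also remains open whether a plain phenyl, or a phenyl ring bearing an amine or a carboxylic acid, would stay with compounds 1, 3 and 4 or step away as compound 2 does.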